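The source may hold more compounds than are shown below. What is called first, only, known or untested is meant among the compounds shown, and "the series" means these compounds.

Working notes, compound 2 to compound 3.

Compound 2 `CCc1ccc(-c2nc3c(=O)n(C)c(=O)n(C)c3[nH]2)cc1` gives, in an assay for binding affinity to adenosine receptor A1 (Bos taurus) (on this read-out higher numbers stand for weaker inhibition and lower numbers for stronger inhibition), a value of 0.8 nM. Within the data shown here, only one other number is in hand: compound 1 `Cn1c(=O)c2nc(-c3ccc(I)cc3)[nH]c2n(C)c1=O` gives 1.3 nM in this assay, and the two numbers lie within the scatter of each other, so neither can be set apart from the other on what is measured.

Among the measured compounds shown here, the single measured step bears directly on the next one: a 1.6-fold lower number from compound 1 to compound 2 (0.21 log units; within the scatter). The move to compound 3 `Cn1c(=O)c2nc(-c3ccc(Br)cc3)[nH]c2n(C)c1=O` is bromo in place of ethyl on an aromatic carbon, at the place where compound 1 carries iodo and compound 2 carries ethyl. For the measured compounds named here, the one step available, iodo to ethyl at this place, stayed within the scatter, and compound 1 with its iodo at the same place gives 1.3 nM, so a bromo there is expected to produce no step beyond the scatter in this assay in either direction.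

For compound 3 the estimate in this assay is 1 nM, with a range of 0.4 nM to 2.5 nM, meaning an expected step of a 1.3-fold higher number from compound 2 to compound 3 (0.10 log units; within the scatter).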

Compound 3, half-maximal inhibitory concentration: 0.75 nM
For compound 3 the middle estimate is 1.3-fold (0.12 log units) above the measured one; the range from low to high includes it.
By their numbers in this assay, from the lowest: compounds 3, 2 and 1 (each within the scatter of the next).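

At this place, on an aromatic carbon para to a large group, bromo in place of ethyl gives a 1.1-fold lower number from compound 2 to compound 3 (0.03 log units; within the scatter) in this assay and bromo in place of iodo gives a 1.7-fold lower number from compound 1 to compound 3 (0.24 log units; within the scatter) in the same assay. Among these compounds, with the earlier iodo to ethyl exchange, all three pairs among iodo, ethyl and bromo now stand within the scatter, where the earlier compounds offered a single pair, and the exchange of ethyl, 2 heavy atoms, for bromo, 1 heavy atom, does not separate the compounds on this read-out. No measurement in hand accounts for this absence of a resolved step.

As far as these compounds go, whether the same flat picture holds for groups of another kind remains open, since an amine, a carboxylic acid or a longer chain such as hexyl at this place could give a step beyond the scatter or none at all. Also open, from the compounds shown here alone, is whether bromo, ethyl and iodo would stay this close on another carbon of the same ring, as all three compounds carry their group at the one place.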